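The compounds below may be only part of what the source reports. "The series", "measured", "known", "first", "only" and "open" are said of these compounds alone.

Compound 1 `Cc1cc(-c2nc3sc(C)cn3c2/C=N/NC(=N)N)c(C)s1` gives 13500 nM in a functional assay on cells (Cancer cell lines, Homo sapiens) for inhibition; a lower number here means a stronger inhibitor of growth, a higher number a weaker inhibitor of growth. Compound 2 `Cc1cn2c(/C=N/NC(=N)N)c(-c3cccs3)nc2s1` gives 18600 nM in this assay. Compound 3 `Cc1cc(-c2nc3n(c2/C=N/NC(=N)N)CCS3)c(C)s1` gives 41700 nM in this assay.

Compound 1 and compound 3 share much of their shape but are built on different cores; the difference between the two cores is not broken down here. Within the first core, the change thiophen-2-yl in place of 2,5-dimethylthiophen-3-yl on an aromatic carbon made a step of a 1.4-fold higher number from compound 1 to compound 2 (0.14 log units; within the scatter). Compound 4 `N=C(N)N/N=C/c1c(-c2cccs2)nc2n1CCS2` is the same kind of change on the core of compound 3, namely (thiophen-2-yl in place of 2,5-dimethylthiophen-3-yl on an aromatic carbon), the place differing only in that it lies two ring bonds from two ring atoms that each bear a fused ring. Because the earlier step of a 1.4-fold higher number from compound 1 to compound 2 (0.14 log units; within the scatter) stayed within the scatter, compound 4 is expected to land close to compound 3, with an estimated step of a 1.3-fold higher number from compound 3 to compound 4 (0.12 log units; within the scatter). The estimate for compound 4 in this assay is 55000 nM, expected between 25000 nM and 120000 nM.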

Compound 4, concentration for total growth inhibition: 40700 nM
Estimate against measurement, compound 4: 1.4-fold (0.13 log units) above; measured number inside the range.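

On the second core, putting thiophen-2-yl in place of 2,5-dimethylthiophen-3-yl gave a 1.0-fold lower number from compound 3 to compound 4 (0.01 log units; within the scatter) in this assay. The change therefore left the number unmoved within the scatter on both cores, and the two steps agree: the same change on two cores in this assay, a 1.4-fold higher number (0.14 log units; within the scatter) from compound 1 to compound 2 and a 1.0-fold lower number (0.01 log units; within the scatter) from compound 3 to compound 4, 1.4-fold (0.15 log units) apart, within the scatter of two such steps. This shows that the swap behaves alike on these two cores, but since neither step is large, it shows only that a null result carried over, not that a real effect did, and two pairs say nothing about other cores.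

On these data alone, what an amine or a carboxylic acid at this same place would do in this assay remains open. So does whether the thiophene ring is needed there at all.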